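The source may report more compounds than this note shows. Statements on the series, on what has been measured and on what is new or still open speak of the compounds shown alone.

Measured compounds in an ADME assay on BaF3 cells (Mus musculus) for antiproliferative activity; a higher number here means a weaker inhibitor of growth, a lower number a stronger inhibitor of growth:
compound 1, `Cc1ccc(NC(=O)c2cccc(C(F)(F)F)c2)cc1OCCNC(=O)c1cccnc1`, > 10000 nM
compound 2, `Cc1ccc(NC(=O)c2cccc(C(F)(F)F)c2)cc1OC1CCN(C(=O)c2cccnc2)CC1`, > 10000 nM
compound 3, `Cc1ccc(NC(=O)c2cc(F)cc(C(F)(F)F)c2)cc1OC1CCN(C(=O)c2cccnc2)CC1`, > 10000 nM

Compound 3 in this assay gives only a limit, > 10000 nM, not a number. The same holds for compound 1, whose value is a limit, and for compound 2, whose value is likewise a limit. For the measured compounds named here, because of the limit of > 10000 nM in this assay, at which 3 of the 3 values shown sit, the one step that connects measured compounds that differ in a single place, a step that the two limits leave unreadable from compound 2 to compound 3, cannot be read in size or direction.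

Compound 4, `Cc1ccc(NC(=O)Nc2ccc(Cl)c(C(F)(F)F)c2)cc1OC1CCN(C(=O)c2cccnc2)CC1`, has not yet been measured in this assay. It differs from compound 3 by (4-chloro-3-(trifluoromethyl)phenyl)amino in place of 3-fluoro-5-(trifluoromethyl)phenyl on a carbonyl carbon. Going by the values given here, no measured step touches this change, and the three limits give no slope from which a direction could be taken. Compound 4 is therefore expected to lie near the limit again, with the step from compound 3 to compound 4 estimated as an at least 1.2-fold lower number from compound 3 to compound 4 (0.09 log units; that floor lies within the scatter), and a wide range around it. The estimate for compound 4 is 8000 nM, between 1000 nM and 30000 nM.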

Compound 4, concentration for 50% growth inhibition: 3300 nM
Beside the measured number, compound 4's estimate is 2.4-fold (0.38 log units) above it, and the stated range covers the measured number.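

In this assay, compound 4 is the first of the compounds shown to give a number rather than a limit, and placing (4-chloro-3-(trifluoromethyl)phenyl)amino on the carbonyl carbon gives an at least 3.0-fold lower number from compound 3 to compound 4 (0.48 log units; beyond the scatter). The same group, set in place of 3-(trifluoromethyl)phenyl, gives an at least 3.0-fold lower number from compound 2 to compound 4 (0.48 log units; beyond the scatter), so both changes on this carbonyl carbon lead to a measurable number, and the true size of each step may be larger than its printed floor. Compound 1, compound 2 and compound 3 each remain a limit, so the step between compound 2 and compound 3 still cannot be read: the limit of > 10000 nM in this assay, at which 3 of the 4 values shown sit.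

The compounds shown do not separate the amino link from the chloro group, as the two enter together. They also leave open what a methoxy group or a dimethylamino group in place of that chloro group would give.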